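The source may report more compounds than this note shows. Statements on the series, on what has been measured and on what is new or still open speak of the compounds shown alone.

Measured in an ADME assay on cells (Fibroblast, Gallus gallus) for cytotoxicity, read by CCK-8 assay, with a stated time of 48 h (a lower number here means that less compound is tolerated, a higher number that more compound is tolerated), all values being limits and not numbers:
- compound 1 `CCC(CC)O[C@@H]1C=C(C(=O)O)C[C@H](NCc2cccc(OC)c2)[C@H]1NC(C)=O`: > 200000 nM
- compound 2 `CCC(CC)O[C@@H]1C=C(C(=O)O)C[C@H](NCc2ccc(OC(C)C)cc2)[C@H]1NC(C)=O`: > 200000 nM
- compound 3 `CCC(CC)O[C@@H]1C=C(C(=O)O)C[C@H](NCc2cccc(SC3CCCC3)c2)[C@H]1NC(C)=O`: > 200000 nM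

Compound 2 stands only at a limit, and compounds 1 and 3 share it: the limit of > 200000 nM in this assay, at which 3 of the 3 values shown sit. Compound 4 `CCC(CC)O[C@@H]1C=C(C(=O)O)C[C@H](NCc2ccc(SC3CCCCC3)cc2)[C@H]1NC(C)=O` carries cyclohexylsulfanyl in place of isopropoxy on an aromatic carbon, para to a large group: cyclohexylsulfanyl in place of isopropoxy on an aromatic carbon. The closest measured change is a step that the two limits leave unreadable from compound 1 to compound 3, which brings in cyclopentylsulfanyl. The other is a step that the two limits leave unreadable from compound 1 to compound 2. Neither gives a size or a direction to carry over. No step beyond the scatter is expected in this assay: a number no higher from compound 2 to compound 4 (the limit leaves the size open). Compound 4 is estimated at 200000 nM, with an expected range of 90000 nM to 300000 nM.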

Compound 4, half-maximal cytotoxic concentration: > 200000 nM
Compound 4 gave a limit, no number; the forecaster's own chance of this, stated with the estimate: 80%; the middle value lies on the limit itself.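

Compound 2 and compound 4 both give only a limit in this assay, so no step between them can be read: the limit of > 200000 nM in this assay, at which 4 of the 4 values shown sit.

The compounds shown leave open whether cyclohexylsulfanyl in place of isopropoxy changes the value in this assay at all, and in which direction.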